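A few compounds are considered here, and "the series" means these few. Any claim that something is new, unique, unknown or untested is made for them only; others in the source may bear on it.

Measured compounds:
- Compound 1 `O=C1Nc2ccc(Br)cc2/C1=C/c1cccc(OCc2cn(Cc3ccccc3)nn2)c1`: in a functional assay on DU-145 cells (Homo sapiens) for inhibition, read by MTT assay, with a stated time of 48 h (a lower number here means a stronger inhibitor, a higher number a weaker inhibitor), compound 1 gives 35100 nM
- Compound 2 `O=C1Nc2cc(Br)ccc2/C1=C\c1cccc(OCc2cn(Cc3ccccc3)nn2)c1`: compound 2 gives 5700 nM
- Compound 3 `O=C1Nc2ccc(F)cc2/C1=C\c1cccc(OCc2cn(Cc3ccccc3)nn2)c1`: compound 3 gives "not determined" (no result reported), that is, no result was reported for it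

The two numbers on record, those of compound 1 and compound 2, span a sizeable range, with compound 2 the stronger inhibitor of the pair. Compound 3 shares the core of compound 1 and compound 2 but carries a fluoro group at the same kind of position, and since no number exists for it, it stands nowhere on the scale; its place can only be guessed from its neighbours.

Compound 4 `COc1ccc(Cc2ccc3c(c2)/C(=C\c2cccc(OCc4cn(Cc5ccccc5)nn4)c2)C(=O)N3)cc1` differs from compound 3 by 4-methoxybenzyl in place of fluoro on an aromatic carbon. Within the data shown here, no step between measured compounds mirrors this swap, so the direction of any shift cannot be read from the data, and the safest expectation is a result in the same broad region as compound 1 and compound 2. Compound 4 is therefore estimated at 10000 nM in this assay, with a range from 2000 nM to 50000 nM.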

Compound 4, half-maximal inhibitory concentration: > 50000 nM
Compound 4: only a limit was reported; the forecaster's own chance of this, stated with the estimate: 15%; middle value at least 5.0-fold (0.69 log units) from the limit.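

Compound 4 gives > 50000 nM, which is a limit and not a number. Among these compounds, compound 3 has no reported result, and no step between compound 3 and compound 4 can be read. On these data alone, what replacing fluoro with 4-methoxybenzyl does to inhibition therefore stays open.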